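Bromo to Chloro on the Sulfonyl Aryl Ring

This account rests on a few compounds, and the source may have more. Where it says the series, first, only, none or still open, it means among the compounds named here.

Compound 1 `CC(O)(CSc1ccc(Cl)cc1)c1nc(-c2ccccc2)no1` gives 70700 nM in a functional assay on DU-145 cells (Homo sapiens) for cytotoxicity, read by MTT assay; on this read-out higher numbers stand for weaker inhibition and lower numbers for stronger inhibition. Compound 2 `CC(O)(CS(=O)(=O)c1ccc(Br)cc1)c1nc(-c2ccccc2)no1` gives > 100000 nM in this assay, which is a limit of the assay and not a number. Compound 3 `CC(O)(CS(=O)(=O)c1ccc(Br)cc1)c1nc(-c2ccc(Cl)cc2)no1` likewise gives > 100000 nM in this assay, again a limit. The step from compound 2 to compound 3 is a step that the two limits leave unreadable from compound 2 to compound 3. Compound 2 therefore stands only at a limit, and the same holds for one further value, as two of the three values shown sit at the limit of > 100000 nM in this assay, at which 2 of the 3 values shown sit.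

Compound 4 `CC(O)(CS(=O)(=O)c1ccc(Cl)cc1)c1nc(-c2ccccc2)no1` differs from compound 2 by chloro in place of bromo on an aromatic carbon. Among the compounds with values here, no measured step follows this exact exchange, and the one step that starts from compound 2 is unreadable, so no change beyond the scatter can be read for it. The step from compound 2 to compound 4 is accordingly expected to be a step that the limit leaves unreadable from compound 2 to compound 4. Compound 4 is estimated to give 150000 nM in this assay, with a range from 50000 nM to 500000 nM.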

Compound 4, half-maximal inhibitory concentration: > 100000 nM
Compound 4: only a limit was reported; the forecaster's own chance of this, stated with the estimate: 80%; the middle value is on the limit's open side.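

Compound 2 and compound 4 both stand only at a limit of the assay, and no step can be read between them: the limit of > 100000 nM in this assay, at which 3 of the 4 values shown sit.

The compounds shown leave open how 4-bromophenyl and 4-chlorophenyl actually compare in this assay, since neither compound has a numerical value.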